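Trimming the Aromatic Group of Compound 3

The source may hold more compounds than are shown below. What is called first, only, known or untested is meant among the compounds shown, and "the series" means these compounds.

Of the compounds shown here, three sharing one core have been tested in a functional assay on MCF7 cells (Homo sapiens) for cytotoxicity, read by MTT assay, with a stated time of 48 h; a higher number here means a weaker inhibitor, a lower number a stronger inhibitor. Compound 1 `O=C1/C(=C\c2ccc([N+](=O)[O-])cc2)S/C(=N/c2ccccc2)N1Cc1ccncc1`, carrying 4-nitrophenyl, gives 13000 nM. Compound 2 `COc1ccc(/C=C2/S/C(=N/c3ccccc3)N(Cc3ccncc3)C2=O)cc1OC`, carrying 3,4-dimethoxyphenyl, gives 80700 nM. Compound 3 `COc1cc(/C=C2/S/C(=N/c3ccccc3)N(Cc3ccncc3)C2=O)ccc1O`, carrying 4-hydroxy-3-methoxyphenyl, gives 28000 nM, the second highest of the three numbers.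

Compound 4 `O=C1/C(=C\c2cccc(O)c2)S/C(=N/c2ccccc2)N1Cc1ccncc1` differs from compound 3 only on a double-bonded chain carbon bound to a double-bonded ring carbon: 3-hydroxyphenyl in place of 4-hydroxy-3-methoxyphenyl on a double-bonded chain carbon bound to a double-bonded ring carbon. The hydroxy group stays, while the methoxy group is absent from the new 3-hydroxyphenyl group.

Among the compounds with values here, no measured step makes exactly this change, so the evidence is indirect. All three measured steps swap the group at this same place, and all are modest. The largest is a 6.2-fold higher number from compound 1 to compound 2 (0.79 log units; beyond the scatter). The smallest is a 2.2-fold higher number from compound 1 to compound 3 (0.33 log units; beyond the scatter). The closest comparison is a 2.9-fold lower number from compound 2 to compound 3 (0.46 log units; beyond the scatter), which replaces methyl with hydrogen on an oxygen on an aromatic ring. These steps do not settle a direction for the new change, so a shift beyond the scatter is not expected.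

The expected result is a 1.1-fold lower number from compound 3 to compound 4 (0.05 log units; within the scatter). Compound 4 is estimated at 25000 nM, with an expected range from 9000 nM to 70000 nM.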

Compound 4, half-maximal inhibitory concentration: 43600 nM
Beside the measured number, compound 4's estimate is 1.7-fold (0.24 log units) below it; the measured number falls inside the stated range.
By their numbers in this assay, from the lowest: compound 1; then compounds 3, 4 and 2 (each within the scatter of the next, the first and the last beyond it).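

In this assay, the 3-hydroxyphenyl group of compound 4 reads much like the 4-hydroxy-3-methoxyphenyl group, with a 1.6-fold higher number from compound 3 to compound 4 (0.19 log units; within the scatter) as the step, so at this position the change does not separate the two groups. The same holds for 3,4-dimethoxyphenyl, with a 1.9-fold lower number from compound 2 to compound 4 (0.27 log units; within the scatter) as the step, which means compound 4 cannot be told apart from compound 2 or compound 3, even though those two can be told apart from each other. The 4-nitrophenyl group stays apart, with a 3.4-fold higher number from compound 1 to compound 4 (0.53 log units; beyond the scatter) as the step, and compound 1 remains the strongest inhibitor of the four, as its steps to all three others lie beyond the scatter.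

Nothing shown here gives a reason for these differences. Still open, on these data alone, is how a plain phenyl, an aminophenyl or a carboxyphenyl group would read at this place, and what the hydroxy group and the methoxy group each contribute alone, as the names of the groups in compound 3 and compound 4 show that both differ in this one step.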